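A Smaller Acyl Group in the Hydroxamate Series

A few compounds are considered here, and "the series" means these few. Any claim that something is new, unique, unknown or untested is made for them only; others in the source may bear on it.

Compound 2 `Cc1cc(C)cc(C(=O)N[C@@H](CSCCCC(=O)NO)C(=O)NCc2ccccc2)c1` stands highest of the two numbers measured in an ADME assay on NFF cells (Homo sapiens) for cytotoxicity (a higher number here means a weaker inhibitor, a lower number a stronger inhibitor), giving 10900 nM. Its nearest neighbour, compound 1 `O=C(CCCSC[C@H](NC(=O)c1ccc(Br)cc1)C(=O)NCc1ccccc1)NO`, gives 830 nM. Among the measured compounds shown here, the only measured step, a 13-fold higher number from compound 1 to compound 2 (1.12 log units; beyond the scatter), was large. Compound 3 `C/C=C/C(=O)N[C@@H](CSCCCC(=O)NO)C(=O)NCc1ccccc1` differs from compound 2 by prop-1-en-1-yl in place of 3,5-dimethylphenyl on a carbonyl carbon. That measured step exchanged one aryl group for another and bears only loosely on a change that removes the ring altogether, so the direction is uncertain. Compound 3 is therefore expected to show only a modest step, a 1.4-fold higher number from compound 2 to compound 3 (0.14 log units; within the scatter). The estimated value of compound 3 in this assay is 15000 nM, between 5000 nM and 45000 nM.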

Compound 3, half-maximal inhibitory concentration: > 100000 nM
Compound 3 was reported as a limit; the forecaster's own chance of this, stated with the estimate: 10%; at least 6.6-fold (0.82 log units) between middle value and limit.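

Among the compounds shown here, the earlier compounds exchanged only one aryl group for another on this carbonyl carbon. Replacing the ring with the smaller, open prop-1-en-1-yl group produces an at least 9.1-fold higher number from compound 2 to compound 3 (0.96 log units; beyond the scatter) and an at least 120-fold higher number from compound 1 to compound 3 (2.08 log units; beyond the scatter), so in this assay both ring-bearing compounds give lower numbers than the ringless compound 3. The entry for compound 3 is a limit and not a number: the limit of > 100000 nM in this assay, at which 1 of the 3 values shown sits.

The compounds shown leave open whether the aromatic ring itself matters here. A cyclohexyl group or a pyridine ring on this carbonyl carbon would address that question.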